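Cyclopropylmethyl to tert-Butyl on the Ring Nitrogen: Tolerability

A few compounds are considered here, and "the series" means these few. Any claim that something is new, unique, unknown or untested is made for them only; others in the source may bear on it.

Compound 1, `CS(=O)(=O)CCCn1c(Cn2c(=O)n(C3COC3)c3ccncc32)cc2cc(Cl)ccc21`: > 50000 nM
Compound 2, `CS(=O)(=O)CCCn1c(Cn2c(=O)n(C3CNC3)c3ccncc32)cc2cc(Cl)ccc21`: > 50000 nM
Compound 3, `CS(=O)(=O)CCCn1c(Cn2c(=O)n(CC3CC3)c3ccncc32)cc2cc(Cl)ccc21`: > 50000 nM

Of the compounds shown here, three sharing one core have been tested in an ADME assay on HeLa cells (Homo sapiens) for cytotoxicity, read by ATP content, with a stated time of 3 days; a higher number here means that more compound is tolerated, a lower number that less compound is tolerated. Compound 1 gives > 50000 nM, which is a limit of the assay and not a number. Compound 2 gives > 50000 nM, again a limit. Compound 3 gives > 50000 nM, also a limit. Compound 3 therefore stands where every value shown stands: the limit of > 50000 nM in this assay, at which 3 of the 3 values shown sit.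

The steps between these compounds cannot be read. From compound 1 to compound 2 the step is a step that the two limits leave unreadable from compound 1 to compound 2; from compound 1 to compound 3 it is a step that the two limits leave unreadable from compound 1 to compound 3; from compound 2 to compound 3 it is a step that the two limits leave unreadable from compound 2 to compound 3. None of them tells how far the tolerated concentration lies beyond the limit.

Compound 4, `CC(C)(C)n1c(=O)n(Cc2cc3cc(Cl)ccc3n2CCCS(C)(=O)=O)c2cnccc21`, has not yet been measured. It differs from compound 3 in one place: tert-butyl in place of cyclopropylmethyl on an aromatic nitrogen. All measured steps that bear on this position are unreadable, so no step in either direction can be predicted beyond the scatter. Compound 4 is expected to sit at the limit as well, with an estimate of 60000 nM in a range from 30000 nM to 150000 nM. This expectation corresponds to a step that the limit leaves unreadable from compound 3 to compound 4.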

Compound 4, half-maximal cytotoxic concentration: > 50000 nM
Compound 4 gave a limit, no number; the forecaster's own chance of this, stated with the estimate: 85%; the middle value lies beyond the limit too.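

Compound 4, like compound 1, compound 2 and compound 3, gives only a limit and not a number, so no step among these four compounds can be read: the limit of > 50000 nM in this assay, at which 4 of the 4 values shown sit.

The compounds shown leave open how far the tolerated concentration in this assay lies beyond the limit for each of them, and whether any group on this aromatic nitrogen would bring it within range.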